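A few compounds are considered here, and "the series" means these few. Any claim that something is new, unique, unknown or untested is made for them only; others in the source may bear on it.

Going by the values given here, in an assay for inhibition of Indoleamine 2,3-dioxygenase 1 (Homo sapiens), with stated times of 10 min and 60 min (on this read-out lower numbers stand for stronger inhibition and higher numbers for weaker inhibition), compound 3 `O=[N+]([O-])c1ccc(Cl)cc1CNc1cc(C(F)(F)F)cc2[nH]ncc12` gives 37700 nM, the higher of the two numbers measured so far. Compound 2 `O=[N+]([O-])c1cc(Cl)ccc1CNc1cc(C(F)(F)F)cc2[nH]ncc12` gives 18000 nM in this assay. Compound 1 `NCCn1ncc2c(NCc3ccccc3[N+](=O)[O-])cc(C(F)(F)F)cc21` reaches only a limit of this assay, reported as > 100000 nM. Compound 4 `O=[N+]([O-])c1ccccc1CNc1cc(C(F)(F)F)cc2[nH]ncc12` has not yet been measured; it differs from compound 3 by hydrogen in place of chloro on an aromatic carbon. Among the compounds with values here, no measured pair isolates this single change, so the step expected here, a 1.2-fold higher number from compound 3 to compound 4 (0.08 log units; within the scatter), is judged to be small, lying within the usual scatter, with only a slight lean toward a higher number. Compound 4 is therefore expected to give about 45000 nM, most likely somewhere between 15000 nM and 130000 nM.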

Compound 4, half-maximal inhibitory concentration: 14000 nM
Compound 4: the middle estimate sits 3.2-fold (0.51 log units) above what was measured; the measured number lies below the stated range.
By their numbers in this assay, from the lowest: compounds 4 and 2 (each within the scatter of the next); then compound 3. At a limit, above all of these: compound 1.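

Hydrogen in place of the chloro para to a nitro group gives a 2.7-fold lower number from compound 3 to compound 4 (0.43 log units; beyond the scatter), so at this position chloro weakens inhibition rather than adding to it. The chloro of compound 2 shows no such cost, with a 1.3-fold lower number from compound 2 to compound 4 (0.11 log units; within the scatter), so the effect depends on where on the ring the chloro sits. Hydrogen in place of 2-aminoethyl on an aromatic nitrogen gives an at least 7.1-fold lower number from compound 1 to compound 4 (0.85 log units; beyond the scatter), and this step rests on a limit, not a number: the limit of > 100000 nM in this assay, at which 1 of the 4 values shown sits.

Only chloro and hydrogen are shown at this position. Going by these compounds, whether a fluoro, a methoxy or an amine there would behave like hydrogen or like chloro stays open.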